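Trimming the side chain: from a benzyl ether to a free hydroxyl

The source may hold more compounds than are shown below. What is called first, only, known or untested is meant among the compounds shown, and "the series" means these compounds.

Three compounds share one core, built around a butyl-bearing acrylic acid attached to a doubly substituted benzene ring that also carries a trifluoromethyl-benzyl ether. In an assay on isolated protein for inhibition of Polyunsaturated fatty acid 5-lipoxygenase (Homo sapiens), read by HPLC, with a stated time of 15 min (a higher number here means a weaker inhibitor, a lower number a stronger inhibitor), compound 1 `CCCC/C(=C\c1cc(Oc2ccccc2)ccc1OCc1ccc(C(F)(F)F)cc1)C(=O)O` gives 2100 nM. Compound 2 `CCCC/C(=C\c1cc(OCc2ccc(CCCC)cc2)ccc1OCc1ccc(C(F)(F)F)cc1)C(=O)O` gives "not active" (no number reported) in this assay, so no number places it on the scale. Compound 3 `CCCC/C(=C\c1cc(OCc2ccc(OCc3ccccc3)cc2)ccc1OCc1ccc(C(F)(F)F)cc1)C(=O)O` likewise gives "not active" (no number reported) in this assay. Compound 4 `CCCC/C(=C\c1cc(O)ccc1OCc1ccc(C(F)(F)F)cc1)C(=O)O` is the untested member: hydrogen in place of 4-butylbenzyl on an oxygen on an aromatic ring, that is, the (4-butylbenzyl)oxy group becomes a hydroxy group. Among the measured compounds shown here, with compound 2 lacking a number, no step can be sized from it, and the direction remains open. Compound 4 is expected to land near 4000 nM in this assay, within a range from 500 nM to 30000 nM.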

Compound 4, half-maximal inhibitory concentration: "not active" (no number reported)
The entry for compound 4 holds no number, so the estimate cannot be set against anything.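

Compound 2 and compound 4 are both reported as not active in this assay and carry no number, so no step can be read between them. As far as these compounds go, how far apart they truly lie stays open. No evidence here bears on this result.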